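Swapping a piperazine amide for a dimethyl amide

The compounds below may be only part of what the source reports. "The series", "measured", "known", "first", "only" and "open" are said of these compounds alone.

- compound 1 `O=C(NCc1ccncc1)C1CCN(C(=O)c2cc3ccccc3n2Cc2ccc(Cl)cc2)CC1`: > 100000 nM, a limit of the assay
- compound 2 `CN1CCN(C(=O)C2CCN(C(=O)c3cc4ccccc4n3Cc3ccc(Cl)cc3)CC2)CC1`: 75600 nM
- compound 3 `Cn1cnc(CNC(=O)C2CCN(C(=O)c3cc4ccccc4n3Cc3ccc(Cl)cc3)CC2)c1`: > 50000 nM, a limit of the assay

In an ADME assay on BE(2)-C cells (Homo sapiens) for cytotoxicity, read by MTT assay, with a stated time of 20 h (a higher number here means that more compound is tolerated, a lower number that less compound is tolerated), compound 2 gives 75600 nM, and it is the only one of the three with an actual number. Compound 1 and compound 3 each carry a limit of the assay instead.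

The next compound to be measured is compound 4 `CN(C)C(=O)C1CCN(C(=O)c2cc3ccccc3n2Cc2ccc(Cl)cc2)CC1`. It keeps the shared core of compound 2 but carries dimethylamino in place of 4-methylpiperazin-1-yl on a carbonyl carbon.

Two measured steps change the group at this same carbonyl carbon. The first is an at least 1.3-fold lower number from compound 1 to compound 2 (0.12 log units; that floor lies within the scatter). The second is a step that the limit leaves unreadable from compound 2 to compound 3. Neither shows a change beyond the scatter, although the first gives only a floor and the second no size at all. The evidence is therefore thin, and none of the three compounds carries the small dimethylamino group.

In this assay no step beyond the scatter is therefore expected, in either direction, and the estimated change is a 1.0-fold lower number from compound 2 to compound 4 (0.00 log units; within the scatter). A report of compound 4 as a limit alone would not be surprising. The estimate for compound 4 is 75000 nM, with an expected range from 35000 nM to 150000 nM.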

Compound 4, half-maximal cytotoxic concentration: > 100000 nM
Compound 4 gave a limit, no number (the forecaster's own chance of this, stated with the estimate: 45%); middle value at least 1.3-fold (0.12 log units) from the limit.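

In this assay, within the data shown here, the first group without a ring at this carbonyl carbon gives an at least 1.3-fold higher number from compound 2 to compound 4 (0.12 log units; that floor lies within the scatter), so dropping the 4-methylpiperazin-1-yl ring for dimethylamino shows no step beyond the scatter, although this is only a floor and the true size stays unknown. Compound 4 carries a limit of the assay and not a number, and it shares this limit with compound 1: the limit of > 100000 nM in this assay, at which 2 of the 4 values shown sit. The steps from compound 1 to compound 4 and from compound 3 to compound 4 cannot be read, so compound 2 remains the only one of the four with an actual number, and the small dimethylamino group adds only one more limit to the series.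

The compounds shown leave open how far the number for compound 4 would lie from that of compound 2 in an assay range reaching further up. They also leave open how this assay would read for other groups on this carbonyl carbon, such as morpholin-4-yl, a plain unsubstituted amine or a hydroxyl group giving a carboxylic acid.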